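A few compounds are considered here, and "the series" means these few. Any claim that something is new, unique, unknown or untested is made for them only; others in the source may bear on it.

Measured in a functional assay on SK-MEL-28 cells (Homo sapiens) for inhibition, read by MTT assay, with a stated time of 72 h; a lower number here means a stronger inhibitor, a higher number a weaker inhibitor:
- Compound 1 `CCC(=O)O[C@@H](/C(C)=C/[C@@H](C)c1oc(CC)c(C)c(=O)c1C)[C@H](C)[C@@H](OC(=O)CC(C)C)[C@@H](C)c1oc([C@@H](C)[C@@H](O)CC)c(C)c(=O)c1C`: 25000 nM
- Compound 2 `CCc1oc([C@H](C)/C=C(\C)[C@H](O)[C@H](C)[C@@H](OC(=O)CC(C)C)[C@@H](C)c2oc([C@@H](C)[C@@H](O)CC)c(C)c(=O)c2C)c(C)c(=O)c1C`: > 100000 nM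

Going by the values given here, compound 1 holds the only actual number in this pair. The entry for compound 2 is a limit of the assay. Compound 3 `CCC(=O)O[C@@H](/C(C)=C/[C@@H](C)c1oc(CC)c(C)c(=O)c1C)[C@H](C)[C@@H](OC(=O)CC(C)C)[C@@H](C)c1oc([C@@H](C)[C@H](CC)OC(C)=O)c(C)c(=O)c1C` is compound 1 with one change, hydroxy to acetoxy: acetyl in place of hydrogen on an oxygen on a saturated carbon. Among the compounds with values here, the one measured step is an at least 4.0-fold higher number from compound 1 to compound 2 (0.60 log units; beyond the scatter) and it put hydrogen in place of propanoyl on a different oxygen. It is only an indirect guide, but it suggests a modestly lower number in this assay when this hydroxy is capped. The expected step is a 2.1-fold lower number from compound 1 to compound 3 (0.32 log units; beyond the scatter). For compound 3 the estimate is 12000 nM, with an expected range from 4000 nM to 40000 nM.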

Compound 3, half-maximal inhibitory concentration: 7000 nM
Compound 3: the middle estimate sits 1.7-fold (0.23 log units) above what was measured; low and high end bracket the measured number.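

In this assay, capping the hydroxy of the 2-hydroxy-1-methylbutyl group as acetoxy gives a 3.6-fold lower number from compound 1 to compound 3 (0.55 log units; beyond the scatter). This free hydroxy is therefore not required for activity, and acylation on this oxygen goes the same way as the propanoyl on the other oxygen did. Nothing measured here accounts for the gain. As far as these compounds go, whether a longer chain on this oxygen, such as butanoyl, or an amine in place of the hydroxy would lower the number further in this assay remains open. So does whether a methyl ether would serve as well as the ester.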